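Amide-side substituent changes on the shared core

The compounds below may be only part of what the source reports. "The series", "measured", "known", "first", "only" and "open" are said of these compounds alone.

Measured so far in an assay on HEK293 cells for displacement of a labelled ligand from Melanocortin receptor 4 (Homo sapiens); a higher number here means a weaker inhibitor, a lower number a stronger inhibitor:
Compound 1 `COc1cc(CC(C)C(=O)N2CCN(c3ccc(C(F)(F)F)cc3[C@@H](N)CC(C)C)CC2)ccc1Cl` gives 230 nM.
Compound 2 `Cc1ccc(OCC(=O)N2CCN(c3ccc(C(F)(F)F)cc3[C@@H](N)CC(C)C)CC2)cc1` gives 4400 nM.
Compound 3 `CC(C)C[C@H](N)c1cc(C(F)(F)F)ccc1N1CCN(C(=O)C(C)Cc2ccc(Cl)cc2O)CC1` gives 36 nM.

Compound 2 is the weakest of the three in this assay: a 19-fold higher number from compound 1 to compound 2 (1.28 log units; beyond the scatter), and a 120-fold lower number from compound 2 to compound 3 (2.09 log units; beyond the scatter), both beyond the scatter. The two stronger compounds share the 1-(benzyl)ethyl arrangement on the carbonyl carbon, and between them a 6.4-fold lower number from compound 1 to compound 3 (0.81 log units; beyond the scatter).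

Compound 4 `Cc1cc(Cl)ccc1CC(C)C(=O)N1CCN(c2ccc(C(F)(F)F)cc2[C@@H](N)CC(C)C)CC1` is not yet measured. Its change from compound 2: 1-(4-chloro-2-methylbenzyl)ethyl in place of (4-methylphenoxy)methyl on a carbonyl carbon. This reverses the kind of change seen in the two steps away from compound 2, which were both large: the step from compound 2 to compound 3 installs a 1-(4-chloro-2-hydroxybenzyl)ethyl, and the step from compound 1 to compound 2 removes a 1-(4-chloro-3-methoxybenzyl)ethyl. The 4-chloro-2-methylbenzyl variant sits between those two in what it carries on the ring, so compound 4 is expected to land between compound 1 and compound 3 in this assay. The expected step is a 29-fold lower number from compound 2 to compound 4 (1.47 log units; beyond the scatter), a large move to a lower number. Compound 4 is estimated at 150 nM, in the range 40 nM to 550 nM.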

Compound 4, inhibition constant: 38 nM
Compound 4: middle estimate off by 3.9-fold (0.60 log units), on the high side, outside the stated range (below it).
By their numbers in this assay, from the lowest: compounds 3 and 4 (each within the scatter of the next); then compound 1; then compound 2.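

In this assay, methyl in place of hydroxy on an aromatic carbon gives a 1.1-fold higher number from compound 3 to compound 4 (0.02 log units; within the scatter) and leaves compound 3 and compound 4 indistinguishable, so the hydrogen-bond donor of the 4-chloro-2-hydroxybenzyl group is not required for a number at this level, as the 1-(4-chloro-2-methylbenzyl)ethyl group has no donor or acceptor. Within the data shown here, the replacement of (4-methylphenoxy)methyl on the carbonyl carbon gives a 120-fold lower number from compound 2 to compound 4 (2.06 log units; beyond the scatter) as a large step, and 4-chloro-2-methylphenyl in place of 4-chloro-3-methoxyphenyl gives a 6.1-fold lower number from compound 1 to compound 4 (0.78 log units; beyond the scatter) in the same direction as a 6.4-fold lower number from compound 1 to compound 3 (0.81 log units; beyond the scatter) for the series so far, so two different ring patterns now both outperform compound 1. No measurement of any property is available to explain these steps.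

The step from compound 2 removes the oxygen, adds the chlorine and alters the chain together, so the share of each remains unresolved. From the compounds shown here alone, how an amine or a carboxylic acid in place of the methyl of compound 4 would read in this assay also remains open.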